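This account rests on a few compounds, and the source may have more. Where it says the series, first, only, none or still open, it means among the compounds named here.

Compound 1 `CCCCNc1nc(N)nc(C)c1CCCC` is a small core carrying a butyl chain on an aromatic carbon. In an assay on HEK293 cells for agonist activity at Toll-like receptor 8 (Homo sapiens), read by spectrophotometry (on this read-out higher numbers stand for an effect only at larger amounts of compound and lower numbers for an effect already at smaller amounts), compound 1 gives 780 nM, the lowest of the two numbers measured. Compound 2 `C#Cc1c(C)nc(N)nc1NCCCC` gives 4900 nM; the step of a 6.3-fold higher number from compound 1 to compound 2 (0.80 log units; beyond the scatter) is the only one measured, and it touches the chain on the aromatic carbon. Compound 3 `CCCCNc1nc(N)nc(C)c1CCCn1cccn1` differs from compound 1 by 1H-pyrazol-1-yl in place of methyl on a saturated chain carbon, three bonds along the chain from an aromatic carbon, a change at the far end of that chain rather than at the aromatic carbon, so the measured step bears on it only loosely. A step of a 1.3-fold lower number from compound 1 to compound 3 (0.11 log units; within the scatter) is expected, within the scatter, and compound 3 is estimated at 600 nM with a range from 200 nM to 2500 nM.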

Compound 3, half-maximal effective concentration: 1050 nM
Compound 3: middle estimate off by 1.8-fold (0.24 log units), on the low side; measured number inside the range.
By their numbers in this assay, from the lowest: compounds 1 and 3 (each within the scatter of the next); then compound 2.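

In this assay, replacing the methyl at the far end of the butyl chain with 1H-pyrazol-1-yl gives a 1.3-fold higher number from compound 1 to compound 3 (0.13 log units; within the scatter), even though a five-membered aromatic ring enters in place of a single carbon. The earlier step changed the whole chain on the aromatic carbon; this one shows that the end of the chain can carry a much larger group while the number stays within the scatter. Nothing measured here says why. From the compounds shown here alone, whether an amine or a carboxylic acid would be accepted at the same place stays open. So does whether a longer chain leading to the 1H-pyrazol-1-yl group would give a similar number.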